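Notes on the step from compound 2 to compound 3

The compounds below may be only part of what the source reports. "The series", "measured", "known", "first", "only" and "open" are said of these compounds alone.

Measured in an ADME assay (liver) for metabolic stability, with Liver microsome (Homo sapiens) as the target, using microsomes and NADPH, with a stated time of 30 min, tested at 1 uM; a higher number here means faster removal of the compound, a lower number slower removal:
- Compound 1 `CCn1cc(-c2cc(C(O)(C(F)(F)F)C(F)(F)F)cnc2N2CCN(S(=O)(=O)c3ccc(N)nc3)CC2)cn1`: 20 mL.min-1.g-1
- Compound 2 `Nc1ccc(S(=O)(=O)N2CCN(c3ncc(C(O)(C(F)(F)F)C(F)(F)F)cc3-c3ccc4ocnc4c3)CC2)cn1`: < 14 mL.min-1.g-1, a limit of the assay and not a number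

Compound 2 has no exact number, so its standing rests on this alone: the limit of < 14 mL.min-1.g-1 in this assay, at which 1 of the 2 values shown sits.

Compound 3 `Nc1ccc(S(=O)(=O)N2CCN(c3ncc(C(O)(C(F)(F)F)C(F)(F)F)cc3-c3ccc4[nH]ncc4c3)CC2)cn1` has not yet been measured. It carries 1H-indazol-5-yl in place of 1,3-benzoxazol-5-yl, on an aromatic carbon of a six-membered aromatic ring with 1 nitrogen, ortho to a large group: 1H-indazol-5-yl in place of 1,3-benzoxazol-5-yl on an aromatic carbon.

Within the data shown here, one measured step bears on this carbon, with 1,3-benzoxazol-5-yl entering in place of 1-ethyl-1H-pyrazol-4-yl: an at least 1.4-fold lower number from compound 1 to compound 2 (0.15 log units; that floor lies within the scatter). It involves a different pair of groups and gives only a floor, so it offers a weak guide to the present change. Among the measured compounds shown here, with an at least 1.4-fold lower number from compound 1 to compound 2 (0.15 log units; that floor lies within the scatter) as the only measured step here, no change beyond the scatter is expected in this assay.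

The expected step is a number no lower from compound 2 to compound 3 (the limit leaves the size open).

For compound 3 the estimate is 14 mL.min-1.g-1, with an expected range of 7 mL.min-1.g-1 to 28 mL.min-1.g-1.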

Compound 3, intrinsic clearance in microsomes: 27 mL.min-1.g-1
Compound 3: middle estimate off by 1.9-fold (0.29 log units), on the low side, and the stated range covers the measured number.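

In this assay, this aromatic carbon of the six-membered aromatic ring with 1 nitrogen has now carried a third group, and the fused 1H-indazol-5-yl and the single-ring 1-ethyl-1H-pyrazol-4-yl cannot be told apart, with a 1.4-fold higher number from compound 1 to compound 3 (0.13 log units; within the scatter). The exchange of one fused group for another, 1H-indazol-5-yl in place of 1,3-benzoxazol-5-yl, gives an at least 1.9-fold higher number from compound 2 to compound 3 (0.28 log units; that floor lies within the scatter), so the two groups of equal heavy-atom count are not yet shown to differ, though the true size of this step may be larger than its floor. Compound 2 holds a limit of the assay and not a number, so this step cannot be sized: the limit of < 14 mL.min-1.g-1 in this assay, at which 1 of the 3 values shown sits.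

Going by these compounds, whether the hydrogen-bond donor present in 1H-indazol-5-yl and absent from 1,3-benzoxazol-5-yl has any bearing on the number remains open, as an exact value for compound 2 would be needed to test it. How a plain phenyl, an amine or a carboxylic acid on this same carbon would read in this assay also remains open, since the compounds shown carry only aromatic heterocycles there.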